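Removing the chloro group from the aryl ketone of compound 3

The source may report more compounds than this note shows. Statements on the series, on what has been measured and on what is new or still open speak of the compounds shown alone.

Three compounds share a core bearing a dimethoxyphenyl group and a phenyl group, joined through a propenone linker to a second aryl ring. Compound 1 `COc1ccc(-c2cc(/C=C/C(=O)c3cc(OC)c(OC)c(OC)c3)nc3cc(-c4ccccc4)nn23)cc1OC` carries a 3,4,5-trimethoxyphenyl group on the carbonyl carbon, and in a functional assay on DU-145 cells (Homo sapiens) for antiproliferative activity, read by MTT assay, with a stated time of 24 h (on this read-out lower numbers stand for stronger inhibition and higher numbers for weaker inhibition), compound 1 gives 8300 nM. Compound 2 `COc1ccc(C(=O)/C=C/c2cc(-c3ccc(OC)c(OC)c3)n3nc(-c4ccccc4)cc3n2)cc1OC` carries a 3,4-dimethoxyphenyl group there, and compound 2 gives 7200 nM; the step of a 1.2-fold lower number from compound 1 to compound 2 (0.06 log units; within the scatter) lies within the scatter. Compound 3 `COc1ccc(-c2cc(/C=C/C(=O)c3ccc(Cl)cc3)nc3cc(-c4ccccc4)nn23)cc1OC` carries a 4-chlorophenyl group on the carbonyl carbon, and compound 3 gives 21300 nM, the highest of the three numbers, with a 2.6-fold higher number from compound 1 to compound 3 (0.41 log units; beyond the scatter) and a 3.0-fold higher number from compound 2 to compound 3 (0.47 log units; beyond the scatter) both beyond the scatter.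

Compound 4 `COc1ccc(-c2cc(/C=C/C(=O)c3ccccc3)nc3cc(-c4ccccc4)nn23)cc1OC` is the next step: hydrogen in place of chloro on an aromatic carbon. For the measured compounds named here, no measured pair tests a chloro against a hydrogen, so the only guidance is that the methoxy-bearing aryl ketones of compound 1 and compound 2 gave lower numbers than compound 3, and compound 4 has neither chloro nor methoxy groups on that ring. Compound 4 is therefore expected to stay close to compound 3, with the step of a 1.2-fold higher number from compound 3 to compound 4 (0.07 log units; within the scatter) estimated as small and likely within the scatter, and compound 4 is estimated at 25000 nM, within a range from 10000 nM to 60000 nM.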

Compound 4, half-maximal inhibitory concentration: 10000 nM
Estimate against measurement, compound 4: 2.5-fold (0.40 log units) above; measured number inside the range.
By their numbers in this assay, from the lowest: compounds 2, 1 and 4 (each within the scatter of the next); then compound 3.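

In this assay the chloro group, on an aromatic carbon para to a large group, now has a direct test, and the step of a 2.1-fold lower number from compound 3 to compound 4 (0.33 log units; beyond the scatter) lies beyond the scatter, so the hydrogen goes with the lower number on this otherwise unchanged scaffold. The bare phenyl ketone also sits with the methoxy-bearing aryl ketones: both a 1.4-fold higher number from compound 2 to compound 4 (0.14 log units; within the scatter) and a 1.2-fold higher number from compound 1 to compound 4 (0.08 log units; within the scatter) lie within the scatter, so in these compounds the lower numbers do not depend on methoxy groups on this ring, and compound 3 alone stands apart from the other three. Nothing available explains why the chloro compound differs in this way.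

The compounds shown leave open whether the higher number is particular to chloro or would also appear with a bromo, a nitrile or an amine on the same carbon. They also leave open how a single methoxy at that carbon would compare, and whether any group there could bring the number clearly below those of compound 1, compound 2 and compound 4.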